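A few compounds are considered here, and "the series" means these few. Any claim that something is new, unique, unknown or untested is made for them only; others in the source may bear on it.

Measured so far:
compound 1 `CCCOCN1c2ccccc2C(=O)NS1(=O)=O`, a functional assay on HEL cells (Homo sapiens); on this read-out higher numbers stand for lower toxicity in this test and lower numbers for higher toxicity in this test: > 50 ug/mL
compound 2 `O=C(OCCOCN1c2ccccc2C(=O)N(Cc2ccccc2)S1(=O)=O)c1ccccc1`, this assay: 17 ug/mL

Compound 1 reaches only a limit of the assay in this assay, > 50 ug/mL, so no number stands for it. Its position is given by the limit of > 50 ug/mL in this assay, at which 1 of the 2 values shown sits. Compound 2 does give a number in this assay, 17 ug/mL. Going by the values given here, neither pair of measured compounds differs in one place, so no measured step is at hand.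

Compound 3 `O=C1NS(=O)(=O)N(COCCO)c2ccccc21` carries the change (hydroxy in place of methyl on a saturated chain carbon, two bonds along the chain from an oxygen on a saturated carbon), that is, hydroxy in place of methyl on a saturated chain carbon, two bonds along the chain from an oxygen on a saturated carbon. With compound 1 standing at a limit, no direction can be read from a measured step. The expected step is a step that the limit leaves unreadable from compound 1 to compound 3, within the scatter. Compound 3 is expected at 60 ug/mL, within 30 ug/mL to 150 ug/mL, most likely again reported only as a limit.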

Compound 3, half-maximal cytotoxic concentration: 112 ug/mL
For compound 3 the middle estimate is 1.9-fold (0.27 log units) below the measured one; the range from low to high includes it.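

No step can be read from compound 1 to compound 3, because compound 1 gives only a limit: the limit of > 50 ug/mL in this assay, at which 1 of the 3 values shown sits. The compounds shown leave open whether hydroxy in place of methyl at this place on the chain changes the half-maximal cytotoxic concentration, and in which direction.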